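Bromo to Chloro Exchange on a Shared Core

This account rests on a few compounds, and the source may have more. Where it says the series, first, only, none or still open, it means among the compounds named here.

Compound 1, `COc1ccc(C(=O)/C=C/c2cccc(Br)c2Oc2c([N+](=O)[O-])cc(C(F)(F)F)cc2[N+](=O)[O-])cc1`, gives 12.7 ug/mL in a functional assay on A549 cells (Homo sapiens) for antiproliferative activity, read by MTT assay, with a stated time of 48 h; on this read-out higher numbers stand for weaker inhibition and lower numbers for stronger inhibition.
Compound 2, `COc1ccc(C(=O)/C=C/c2cccc(Cl)c2Oc2c([N+](=O)[O-])cc(C(F)(F)F)cc2[N+](=O)[O-])cc1`, gives 11.5 ug/mL in this assay.
Compound 3, `O=C(/C=C/c1cccc(Br)c1Oc1c([N+](=O)[O-])cc(C(F)(F)F)cc1[N+](=O)[O-])c1ccc(F)cc1`, gives 26.3 ug/mL in this assay.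

Compound 4, `O=C(/C=C/c1cccc(Cl)c1Oc1c([N+](=O)[O-])cc(C(F)(F)F)cc1[N+](=O)[O-])c1ccc(F)cc1`, has not been measured. It differs from compound 3 by one change: chloro in place of bromo on an aromatic carbon. The same kind of change occurs from compound 1 to compound 2: chloro in place of bromo on an aromatic carbon. There it made a 1.1-fold lower number from compound 1 to compound 2 (0.04 log units; within the scatter). The two cores differ in one place: fluoro in place of methoxy on an aromatic carbon, and that change made a 2.1-fold higher number from compound 1 to compound 3 (0.32 log units; beyond the scatter). The surroundings of the exchanged halogen are not identical, since in compound 3 the place is meta to a 2-((4-fluorophenyl)carbonyl)ethenyl group rather than a 2-((4-methoxyphenyl)carbonyl)ethenyl group, so the change is the same kind, not the same. Because a 1.1-fold lower number from compound 1 to compound 2 (0.04 log units; within the scatter) lay within the scatter, a similarly small step, a 1.1-fold lower number from compound 3 to compound 4 (0.04 log units; within the scatter), is expected from compound 3 to compound 4. Compound 4 is therefore estimated at 24 ug/mL in this assay, most likely between 13 ug/mL and 45 ug/mL.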

Compound 4, half-maximal inhibitory concentration: 23.8 ug/mL
Compound 4: the middle estimate sits 1.0-fold (0.00 log units) above what was measured, and the stated range covers the measured number.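

In this assay, chloro in place of bromo gave a 1.1-fold lower number from compound 3 to compound 4 (0.04 log units; within the scatter), and this exchange behaved alike on both cores: the same change on two cores in this assay, a 1.1-fold lower number (0.04 log units; within the scatter) from compound 1 to compound 2 and a 1.1-fold lower number (0.04 log units; within the scatter) from compound 3 to compound 4, 1.0-fold (0.00 log units) apart, within the scatter of two such steps. Fluoro in place of methoxy gave a 2.1-fold higher number from compound 2 to compound 4 (0.32 log units; beyond the scatter), matching what the same change did when bromo was present: the same change on two cores in this assay, a 2.1-fold higher number (0.32 log units; beyond the scatter) from compound 1 to compound 3 and a 2.1-fold higher number (0.32 log units; beyond the scatter) from compound 2 to compound 4, 1.0-fold (0.00 log units) apart, within the scatter of two such steps. Each change therefore carried over from one core to the other here, but four compounds show this only for these two exchanges in this one assay, and they do not show why it happens.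

Still open, on these data alone, is whether the same holds for other groups in the halogen's place, such as a nitrile or a methyl group. Also open, as far as these compounds go, is what an amine would do in place of the methoxy or fluoro group.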